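Aryl Swap at the Ring Nitrogen: Compound 3 to Compound 4

The source may report more compounds than this note shows. Statements on the series, on what has been measured and on what is new or still open speak of the compounds shown alone.

Compound 1, `CCCCCCNc1nc(SCc2ccc(C(F)(F)F)cc2)nc2ccccc12`, in a functional assay on PC-3 cells (Homo sapiens) for cytotoxicity, read by MTT assay, with a stated time of 72 h (a higher number here means a weaker inhibitor, a lower number a stronger inhibitor), gives 19000 nM.
Compound 2, `CCCCCCCCCCCCCCNc1nc(SCc2ccc(C(F)(F)F)cc2)nc2ccccc12`, in this assay reaches only a limit of the assay, > 50000 nM.
Compound 3, `FC(F)(F)c1ccc(CSc2nc(Nc3ccccc3C(F)(F)F)c3ccccc3n2)cc1`, in this assay gives 34800 nM.

Of the two numbers in hand, compound 3 sits nearest to compound 1, and the gap between them, a 1.8-fold higher number from compound 1 to compound 3 (0.26 log units; within the scatter), stays within the scatter; the third value, that of compound 2, is a limit only, as the limit of > 50000 nM in this assay, at which 1 of the 3 values shown sits, records. The next compound, compound 4, `FC(F)(F)c1ccc(CSc2nc(Nc3cccc(Br)c3)c3ccccc3n2)cc1`, differs from compound 3 in one place: 3-bromophenyl in place of 2-(trifluoromethyl)phenyl on a nitrogen on an aromatic ring.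

Two measured steps exist. The step of an at least 2.6-fold higher number from compound 1 to compound 2 (0.42 log units; beyond the scatter) lengthens the chain on the ring nitrogen and lies away from the present change. The step of a 1.8-fold higher number from compound 1 to compound 3 (0.26 log units; within the scatter) exchanges hexyl for 2-(trifluoromethyl)phenyl on that same nitrogen and stays within the scatter, so a substituent swap at this position has so far moved the number little. For the measured compounds named here, no measured step exchanges one aryl group for another here, so the direction of any shift is open, and no step beyond the scatter is expected.

Compound 4 is therefore estimated at 30000 nM, between 10000 nM and 80000 nM, which means an expected step of a 1.2-fold lower number from compound 3 to compound 4 (0.06 log units; within the scatter).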

Compound 4, half-maximal inhibitory concentration: 8680 nM
Estimate against measurement, compound 4: 3.5-fold (0.54 log units) above; the whole stated range lies above it.
By their numbers in this assay, from the lowest: compound 4; then compounds 1 and 3 (each within the scatter of the next). At a limit, above all of these: compound 2.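

In this assay, for the compounds shown here, the exchange of 2-(trifluoromethyl)phenyl for 3-bromophenyl on the nitrogen is the only aryl-for-aryl step at this position, and it lies beyond the scatter (a 4.0-fold lower number from compound 3 to compound 4 (0.60 log units; beyond the scatter)). The number at this position therefore depends on which aryl group the nitrogen carries, something the exchange of hexyl for 2-(trifluoromethyl)phenyl, which stayed within the scatter, did not show; an aryl group can also separate from hexyl, as 3-bromophenyl does (a 2.2-fold lower number from compound 1 to compound 4 (0.34 log units; beyond the scatter)). Nothing in the data shown bears on why the number moves with this change.

The step from compound 3 to compound 4 changes both the substituent and the place it occupies on the phenyl ring, so the compounds shown cannot divide the shift between the two, and 3-(trifluoromethyl)phenyl or 2-bromophenyl on the same nitrogen would be needed to separate them. As far as these compounds go, how an unsubstituted phenyl, a 3-chlorophenyl or a phenyl ring carrying an amine or a carboxylic acid would compare at this nitrogen also remains open.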